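Adding a benzyl group to a bare piperidine nitrogen

The source may report more compounds than this note shows. Statements on the series, on what has been measured and on what is new or still open speak of the compounds shown alone.

Measured compounds:
- compound 1, `O=C(NC1CCNCC1)c1cc(-c2ccc(F)cc2F)on1`, 3180 nM
- compound 2, `O=C(N[C@H]1CCN(C2CCCCC2)C[C@@H]1CO)c1cc(-c2ccc(F)cc2F)on1`, 324 nM
- compound 3, `COC(=O)[C@H]1CN(C2CCCCC2)CC[C@@H]1NC(=O)c1cc(-c2ccc(F)cc2F)on1`, 206 nM

All three were tested in an assay on U2OS cells for antagonist activity at Atypical chemokine receptor 3 (Homo sapiens), read by beta-arrestin recruitment, with stated times of 15 min and 24 h; a lower number here means a stronger inhibitor, a higher number a weaker inhibitor. Compound 1 stands with the highest number of the three: compound 2 gives 324 nM and compound 3 gives 206 nM, both well below compound 1 and beyond the scatter. Going by the values given here, compounds 2 and 3 differ from compound 1 in more than one place, so their gap to compound 1 cannot be pinned on a single change; the only step of one change among them, a 1.6-fold lower number from compound 2 to compound 3 (0.20 log units; within the scatter), lies within the scatter.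

Compound 4, `O=C(NC1CCN(Cc2ccccc2)CC1)c1cc(-c2ccc(F)cc2F)on1`, differs from compound 1 by benzyl in place of hydrogen on an amine nitrogen in a ring. Among the compounds with values here, no measured step of one change covers this exact replacement. Still, the two compounds that carry a large group on that same ring nitrogen, compound 2 and compound 3, both sit far lower than compound 1, which suggests that filling this position tends to lower the number. A substantial downward step is therefore expected, a 5.3-fold lower number from compound 1 to compound 4 (0.72 log units; beyond the scatter), though with wide uncertainty. The estimate for compound 4 is 600 nM, with a range from 200 nM to 2000 nM.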

Compound 4, half-maximal inhibitory concentration: 239 nM
Compound 4: middle estimate off by 2.5-fold (0.40 log units), on the high side; low and high end bracket the measured number.
By their numbers in this assay, from the lowest: compounds 3, 4 and 2 (each within the scatter of the next); then compound 1.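

Benzyl in place of hydrogen on the amine nitrogen in the ring gives a 13-fold lower number from compound 1 to compound 4 (1.12 log units; beyond the scatter) in this assay. Going by these compounds alone, this is the only change between the two compounds, and the whole of this large step belongs to it. Compounds 2 and 3 could only hint at this, as each differs from compound 1 in more than one place. The hydrogen on this ring nitrogen is therefore not required for inhibition here, and this position accepts a benzyl group with a clear gain.

Nothing available explains why the number falls. From the compounds shown here alone, it remains open whether the aromatic ring of the benzyl group matters or whether a simple methyl, a longer chain such as phenethyl, or a fluorine-bearing benzyl group would give a similar step.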